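The source may report more compounds than this note shows. Statements on the series, on what has been measured and on what is new or still open speak of the compounds shown alone.

Measured so far in a functional assay on OCI-Ly3 cells (Homo sapiens) for inhibition, read by CellTiter-Glo, with stated times of 48 h and 96 h; on this read-out higher numbers stand for weaker inhibition of growth and lower numbers for stronger inhibition of growth
compound 1 `CC(C)[C@H](NC(=O)c1cccc(Br)c1)C(=O)N1CCC[C@H]1C(=O)N[C@@H](CCCNC(=N)N)C(=O)CF` gives 530 nM
compound 2 `CC(C)[C@H](NC(=O)c1ccc(Cl)cc1)C(=O)N1CCC[C@H]1C(=O)N[C@@H](CCCNC(=N)N)C(=O)CF` gives 1240 nM
compound 3 `CC(C)[C@H](NC(=O)c1ccc(C#N)cc1)C(=O)N1CCC[C@H]1C(=O)N[C@@H](CCCNC(=N)N)C(=O)CF` gives 6660 nM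

Compound 3 has the highest number of the three, which means the weakest inhibition of growth. Compound 4 `CC(C)[C@H](NC(=O)Nc1ccccc1)C(=O)N1CCC[C@H]1C(=O)N[C@@H](CCCNC(=N)N)C(=O)CF` differs from it in one place (anilino in place of 4-cyanophenyl on a carbonyl carbon): anilino in place of 4-cyanophenyl on a carbonyl carbon. For the measured compounds named here, two steps bear on this, both arriving at 4-cyanophenyl: a large one (a 13-fold higher number from compound 1 to compound 3 (1.10 log units; beyond the scatter)) and a modest one (a 5.4-fold higher number from compound 2 to compound 3 (0.73 log units; beyond the scatter)). Going by the values given here, no measured compound carries anilino, so they are only a rough guide. Leaving 4-cyanophenyl is expected to bring a modest fall in this assay (a 3.3-fold lower number from compound 3 to compound 4 (0.52 log units; beyond the scatter)). The expected value for compound 4 is 2000 nM with a range from 500 nM to 7000 nM as estimated.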

Compound 4, concentration for 50% growth inhibition: 1520 nM
Beside the measured number, compound 4's estimate is 1.3-fold (0.12 log units) above it, and the stated range covers the measured number.
By their numbers in this assay, from the lowest: compound 1; then compounds 2 and 4 (each within the scatter of the next); then compound 3.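

In this assay, anilino on this carbonyl carbon recovers much of what 4-cyanophenyl loses (a 4.4-fold lower number from compound 3 to compound 4 (0.64 log units; beyond the scatter)), so a ring attached through nitrogen is tolerated here even without a substituent. It cannot be told apart from 4-chlorophenyl (a 1.2-fold higher number from compound 2 to compound 4 (0.09 log units; within the scatter)) but stays weaker than 3-bromophenyl (a 2.9-fold higher number from compound 1 to compound 4 (0.46 log units; beyond the scatter)). Nothing available explains these differences.

The compounds shown leave open whether a methoxy group or a carboxylic acid on the anilino ring would shift the number. They also leave open how benzylamino would compare on the same carbonyl carbon.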